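A few compounds are considered here, and "the series" means these few. Any claim that something is new, unique, unknown or untested is made for them only; others in the source may bear on it.

Compound 1, `c1ccc(C(/N=C2\CCCCCN2)C2CCC2)cc1`, is one of two compounds that have been tested in a functional assay on the whole organism (plasma, strain Sprague-Dawley) with Rattus norvegicus as the target, with a stated time of 2 h, at a dose of 12.5 mg/kg by the oral route; a lower number here means a weaker effect, a higher number a stronger effect of the compound at the dose given. In this assay compound 1 gives 14%. The other tested compound, compound 2, `c1ccc(C(/N=C2\CCCCN2)c2ccco2)cc1`, gives 13% in this assay. These two numbers lie within the usual scatter of one another, so compound 1 does not stand apart from compound 2 on the numbers shown, and no step between the two has been worked out.

Compound 3, `c1ccc(C(/N=C2\CCCCCN2)c2ccco2)cc1`, has not yet been measured in this assay. It differs from compound 1 in one place: furan-2-yl in place of cyclobutyl on a saturated chain carbon bound to an aromatic carbon and a double-bonded nitrogen. Among the measured compounds shown here, no measured pair shows this change directly, so the step it brings is open. The account expects the step from compound 1 to compound 3 to be small, no change at the digits printed from compound 1 to compound 3 (within the scatter), with no change beyond the scatter, since compound 2, which carries the same furan-2-yl group, gives 13%. For compound 3 the expected value in this assay is therefore 14%, within a range from 3% to 27%.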

Compound 3, a percentage reported as inhibition, in the whole organism at one dose (the size of the read-out at that dose, not a potency): 5%
The estimate for compound 3 lay 9 percentage points above the measured number; the measured number falls inside the stated range.
By their numbers in this assay, from the lowest: compounds 3, 2 and 1 (each within the scatter of the next).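

Among the compounds shown here, replacing cyclobutyl with furan-2-yl on a saturated chain carbon bound to an aromatic carbon and a double-bonded nitrogen gives a number 9 percentage points lower from compound 1 to compound 3 (within the scatter) in this assay and so supplies the first direct reading of this change. At this single dose, the two groups cannot be told apart at this place, and the exchange of a four-membered non-aromatic ring of carbon only for a five-membered aromatic ring with one hetero atom does not register beyond the scatter. No evidence at hand bears on this reading.

The compounds shown leave open whether any group at this place can move the read-out beyond the scatter. As far as these compounds go, what an amine, a carboxylic acid or a longer chain would give at the same place remains unknown.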